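Swapping the aryl group on the piperazine ring toward difluorophenyl

The source may hold more compounds than are shown below. What is called first, only, known or untested is meant among the compounds shown, and "the series" means these compounds.

Measured compounds:
compound 1 `Nc1scc(CN2CCN(c3cc(Cl)cc(Cl)c3)CC2)c1C(=O)c1ccc(Cl)cc1`: -1%
compound 2 `Nc1scc(CN2CCN(c3cccc4ccccc34)CC2)c1C(=O)c1ccc(Cl)cc1`: 8.7%
compound 3 `Nc1scc(CN2CCN(c3cccc(F)c3)CC2)c1C(=O)c1ccc(Cl)cc1`: -18%

All three compounds share one core and differ only in the aromatic group attached to the amine nitrogen in the ring. They were tested in a functional assay on CHO cells with adenosine receptor A1 (Homo sapiens) as the target, read by cAMP accumulation and immunoassay, with a stated time of 6 min, tested at 0.01 uM; a higher number here means a weaker effect of the compound at the concentration tested, a lower number a stronger effect. Compound 1 and compound 2 sit within the scatter of each other, shown by a number 9.7 percentage points higher from compound 1 to compound 2 (within the scatter). Compound 3 lies further off: a number 17 percentage points lower from compound 1 to compound 3 (beyond the scatter), and likewise a number 26.7 percentage points lower from compound 2 to compound 3 (beyond the scatter).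

The next compound, compound 4 `Nc1scc(CN2CCN(c3ccc(F)c(F)c3)CC2)c1C(=O)c1ccc(Cl)cc1`, is not yet measured. It differs from compound 1 as follows: 3,4-difluorophenyl in place of 3,5-dichlorophenyl on an amine nitrogen in a ring. For the measured compounds named here, the one measured step that bears on this change is the move from dichlorophenyl to a fluorinated phenyl, a number 17 percentage points lower from compound 1 to compound 3 (beyond the scatter), a modest drop beyond the scatter. On that basis a step in the same direction, of similar or somewhat smaller size, is expected for compound 4, that is a number 9 percentage points lower from compound 1 to compound 4 (within the scatter), because a number 17 percentage points lower from compound 1 to compound 3 (beyond the scatter) points that way. Compound 4 is therefore estimated at -10%, with a likely range from -30% to 10%.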

Compound 4, a percentage reported as activity, at one concentration (the size of the read-out at that concentration, not a potency): -3.2%
For compound 4 the middle estimate is 6.8 percentage points below the measured one; measured number inside the range.
By their numbers in this assay, from the lowest: compound 3; then compounds 4, 1 and 2 (each within the scatter of the next, the first and the last beyond it).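

In this assay, replacing 3,5-dichlorophenyl with 3,4-difluorophenyl on the amine nitrogen leaves the reading essentially unchanged, with a number 2.2 percentage points lower from compound 1 to compound 4 (within the scatter). Fluorine on the phenyl ring is therefore not enough to reach the lowest number in the series: adding fluoro in place of hydrogen on an aromatic carbon gives a number 14.8 percentage points higher from compound 3 to compound 4 (beyond the scatter), while replacing naphthalen-1-yl gives a number 11.9 percentage points lower from compound 2 to compound 4 (beyond the scatter). No measurement shown here accounts for these differences.

These compounds leave open whether the low number with 3-fluorophenyl is specific to that single-fluorine group or would also appear with other small groups on the phenyl ring. They also do not show how a methoxyphenyl or pyridyl group on the same amine nitrogen would read.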